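The compounds below may be only part of what the source reports. "The series", "measured", "known", "first", "only" and "open" are said of these compounds alone.

Three measured compounds share a core and differ in their peptide portion. Compound 2 `COc1ccc(/C=C\c2cc(OC)c(OC)c(OC)c2)cc1NC(=O)[C@H](C)NC(=O)[C@H](CCCNC(=N)N)NC(=O)[C@H](CCCNC(=N)N)NC(=O)c1ccccc1` gives 65.7 nM in an ADME assay on HeLa cells (Homo sapiens) for cytotoxicity, with a stated time of 72 h; a lower number here means that less compound is tolerated, a higher number that more compound is tolerated. Compound 1 `COc1ccc(/C=C\c2cc(OC)c(OC)c(OC)c2)cc1NC(=O)[C@H](C)NC(=O)[C@H](CCCNC(=N)N)NC(=O)[C@H](CCCCN)NC(=O)c1ccccc1` gives 24.6 nM in this assay, so the step of a 2.7-fold lower number from compound 2 to compound 1 (0.43 log units; beyond the scatter) goes with the change (a group of 2 heavy atoms (1 carbon, 1 nitrogen; no ring) in place of a group of 4 heavy atoms (1 carbon, 3 nitrogen; no ring), on a saturated chain carbon, four bonds along the chain from an amide-type nitrogen and a carbonyl carbon). Compound 3 `COc1ccc(/C=C\c2cc(OC)c(OC)c(OC)c2)cc1NC(=O)CNC(=O)[C@H](CCCNC(=N)N)NC(=O)[C@H](CCCNC(=N)N)NC(=O)c1ccccc1` gives 7.2 nM, which is the lowest of the three numbers; the step of a 9.1-fold lower number from compound 2 to compound 3 (0.96 log units; beyond the scatter) goes with the change (hydrogen in place of methyl on a saturated chain carbon bound to an amide-type nitrogen and a carbonyl carbon), and this change is also how the cores of compound 2 and compound 3 differ.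

Compound 4 `COc1ccc(/C=C\c2cc(OC)c(OC)c(OC)c2)cc1NC(=O)CNC(=O)[C@H](CCCNC(=N)N)NC(=O)[C@H](CCCCN)NC(=O)c1ccccc1` is not yet measured in this assay. It differs from compound 3 by a group of 2 heavy atoms (1 carbon, 1 nitrogen; no ring) in place of a group of 4 heavy atoms (1 carbon, 3 nitrogen; no ring), on a saturated chain carbon, four bonds along the chain from an amide-type nitrogen and a carbonyl carbon, which is the same change that was made from compound 2 to compound 1, at the same place. Because the earlier step of a 2.7-fold lower number from compound 2 to compound 1 (0.43 log units; beyond the scatter) was modest and beyond the scatter, he expects a step of about the same size, a 2.6-fold lower number from compound 3 to compound 4 (0.41 log units; beyond the scatter), when the change is carried onto compound 3. On that basis compound 4 is estimated at 2.8 nM, with a range expected from 1.2 nM to 7.5 nM.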

Compound 4, half-maximal cytotoxic concentration: 78.2 nM
Beside the measured number, compound 4's estimate is 28-fold (1.45 log units) below it, outside the stated range (above it).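

In this assay, putting aminomethyl in place of the group of 4 heavy atoms on the core of compound 3 gives an 11-fold higher number from compound 3 to compound 4 (1.04 log units; beyond the scatter), opposite in direction to the earlier step, so this change did not carry from one core to the other: the same change on two cores in this assay, a 2.7-fold lower number (0.43 log units; beyond the scatter) from compound 2 to compound 1 and an 11-fold higher number (1.04 log units; beyond the scatter) from compound 3 to compound 4, 29-fold (1.46 log units) apart, beyond the scatter of two such steps. The second change, hydrogen in place of methyl on a saturated chain carbon bound to an amide-type nitrogen and a carbonyl carbon, also reverses, with a 3.2-fold higher number from compound 1 to compound 4 (0.50 log units; beyond the scatter), so in these four compounds the outcome of each change depends on the other: the same change on two cores in this assay, a 9.1-fold lower number (0.96 log units; beyond the scatter) from compound 2 to compound 3 and a 3.2-fold higher number (0.50 log units; beyond the scatter) from compound 1 to compound 4, 29-fold (1.46 log units) apart, beyond the scatter of two such steps. This does not show why the two changes depend on each other, and four compounds give no rule for any further core.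

The compounds shown leave open whether the reversal would also appear with a longer chain ending in an amine, or with a carboxylic acid, at the same place. They also leave open whether it would persist with ethyl in place of the methyl.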